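Moving One Methoxy Group on the Ring Nitrogen Substituent

The source may report more compounds than this note shows. Statements on the series, on what has been measured and on what is new or still open speak of the compounds shown alone.

Three compounds share a core and differ only in the group on the amide-type nitrogen in the ring. In a functional assay on MG-63 cells (Homo sapiens) for inhibition, read by CCK-8 assay, with a stated time of 72 h, tested at 1 uM (a lower number here means less inhibition, a higher number more inhibition at the concentration tested (going by the name of the read-out)), compound 1 `COc1ccc(C)cc1N1C(=O)CSC1c1cccc(C(=O)NCCCCc2ccccc2)c1` gives 92%, compound 2 `COc1cc(F)ccc1N1C(=O)CSC1c1cccc(C(=O)NCCCCc2ccccc2)c1` gives 92%, and compound 3 `COc1cccc(OC)c1N1C(=O)CSC1c1cccc(C(=O)NCCCCc2ccccc2)c1` gives 80%. Compound 3 stands lowest of the three: a number 12 percentage points lower from compound 1 to compound 3 (beyond the scatter) and a number 12 percentage points lower from compound 2 to compound 3 (beyond the scatter) both fall beyond the scatter, while no change at the digits printed from compound 1 to compound 2 (within the scatter). Compound 4 `COc1ccc(N2C(=O)CSC2c2cccc(C(=O)NCCCCc3ccccc3)c2)c(OC)c1` is not yet measured; it differs from compound 3 by 2,4-dimethoxyphenyl in place of 2,6-dimethoxyphenyl on an amide-type nitrogen in a ring. The two downward steps bear on this change, since each ended at the 2,6-dimethoxyphenyl that compound 4 now gives up, so a modest recovery is expected. The expected step is a number 8 percentage points higher from compound 3 to compound 4 (within the scatter). Compound 4 is estimated at 88%, with a range from 78% to 96%.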

Compound 4, a percentage reported as inhibition, at one concentration (the size of the read-out at that concentration, not a potency): 56%
Compound 4: middle estimate off by 32 percentage points, on the high side; the measured number lies below the stated range.
By their numbers in this assay, from the lowest: compound 4; then compound 3; then compounds 1 and 2 (each within the scatter of the next).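

Swapping 2,6-dimethoxyphenyl for 2,4-dimethoxyphenyl keeps the same atoms and counts, yet in this assay the number falls (a number 24 percentage points lower from compound 3 to compound 4 (beyond the scatter)), so at this position the arrangement of the two methoxy groups matters, not only their presence. The gap is wider against the other two compounds (a number 36 percentage points lower from compound 2 to compound 4 (beyond the scatter); a number 36 percentage points lower from compound 1 to compound 4 (beyond the scatter)), and the first of these is a change of fluoro to methoxy on an aromatic carbon. Nothing available explains the fall.

Open, on these data alone, is whether an amine or a carboxylic acid in place of the second methoxy of the 2,4-dimethoxyphenyl would give a similarly low number.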